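The compounds below may be only part of what the source reports. "The series", "measured", "known", "first", "only" and "open" are said of these compounds alone.

Measured compounds:
Compound 1 `COc1cc(-c2cc(/C=C/C(=O)c3ccc(Cl)c(Cl)c3)[nH]n2)cc(OC)c1OC` — in a functional assay on MDA-MB-231 cells (Homo sapiens) for cytotoxicity, read by sulforhodamine B assay, with a stated time of 48 h, tested at 0.1 uM (a lower number here means a stronger effect, a higher number a weaker effect of the compound at the concentration tested), compound 1 gives 102%.
Compound 2 `COc1ccc(C(=O)/C=C/c2cc(-c3cc(OC)c(OC)c(OC)c3)n[nH]2)cc1OC` — in this assay compound 2 gives 101%.
Compound 3 `COc1cc(-c2cc(/C=C/C(=O)c3ccc(F)c(F)c3)[nH]n2)cc(OC)c1OC` — in this assay compound 3 gives 96%.

All three compounds share one core and differ only in the aryl group attached to the carbonyl carbon. Compound 2 holds the second highest of the three numbers; its nearest neighbour is compound 1, with a number 1 percentage points lower from compound 1 to compound 2 (within the scatter), and its furthest is compound 3, with a number 5 percentage points lower from compound 2 to compound 3 (within the scatter). Both steps stay within the scatter, as does a number 6 percentage points lower from compound 1 to compound 3 (within the scatter), so the three values show no separation between them.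

Compound 4 `COc1cc(C(=O)/C=C/c2cc(-c3cc(OC)c(OC)c(OC)c3)n[nH]2)cc(OC)c1OC` has not yet been measured. It differs from compound 2 by methoxy in place of hydrogen on an aromatic carbon. The step that bears on it is the pair of exchanges of the aryl group on the carbonyl carbon, from compound 1 to compound 2 and from compound 2 to compound 3; neither moved the read-out beyond the scatter. The change to compound 4 is smaller than either of those, a single methoxy entering on the same ring. In this assay no step beyond the scatter is therefore expected for compound 4, and the estimated step from compound 2 is a number 1 percentage points lower from compound 2 to compound 4 (within the scatter). For compound 4 the expected value is 100%, within an estimated range from 88% to 110%.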

Compound 4, a percentage reported as activity, at one concentration (the size of the read-out at that concentration, not a potency): 104%
Compound 4: middle estimate off by 4 percentage points, on the low side, and the stated range covers the measured number.
By their numbers in this assay, from the lowest: compounds 3, 2, 1 and 4 (each within the scatter of the next).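

For the compounds shown here, until now the only changes were exchanges of the whole aryl group on the carbonyl carbon; compound 4 instead adds a single substituent to that ring, methoxy in place of hydrogen on an aromatic carbon, ortho to a methoxy group. In this assay this change gives a number 3 percentage points higher from compound 2 to compound 4 (within the scatter), so at this position the added methoxy does not separate the two compounds at the concentration tested. No available evidence bears on this result.

The compounds shown leave open whether another group at this position, such as an amine, a carboxylic acid or a longer alkoxy chain, would move the read-out beyond the scatter. They also leave open whether any of these four compounds would separate from the others at a higher concentration.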